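Amide aryl variation on the shared core

This account rests on a few compounds, and the source may have more. Where it says the series, first, only, none or still open, it means among the compounds named here.

Measured in a functional assay on HCC1937 cells (Homo sapiens) for antiproliferative activity, read by CCK-8 assay, with a stated time of 72 h; on this read-out higher numbers stand for weaker inhibition and lower numbers for stronger inhibition:
compound 1 `O=C(Nc1cccc(-c2oc3cc(-c4ccc(F)cc4)ccc3c(=O)c2O)c1)c1ccc(Cl)cc1` gives 4030 nM
compound 2 `O=C(Nc1cccc(-c2oc3cc(-c4ccc(F)cc4)ccc3c(=O)c2O)c1)c1ccc(F)cc1F` gives 6980 nM

For the measured compounds named here, compound 2 holds the higher of the two numbers in this assay, but the only step, a 1.7-fold higher number from compound 1 to compound 2 (0.24 log units; within the scatter), lies within the scatter, so the two values do not separate. Compound 3 `Cc1ccccc1C(=O)Nc1cccc(-c2oc3cc(-c4ccc(F)cc4)ccc3c(=O)c2O)c1` arises from compound 2 by 2-methylphenyl in place of 2,4-difluorophenyl on a carbonyl carbon. Going by the values given here, no measured step covers this exchange; the one step seen, a 1.7-fold higher number from compound 1 to compound 2 (0.24 log units; within the scatter), was small. The step expected here, a 1.3-fold lower number from compound 2 to compound 3 (0.10 log units; within the scatter), is therefore none beyond the scatter. Compound 3 is estimated at 5500 nM, with a range from 2000 nM to 15000 nM.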

Compound 3, half-maximal inhibitory concentration: 9900 nM
Beside the measured number, compound 3's estimate is 1.8-fold (0.26 log units) below it; measured number inside the range.
By their numbers in this assay, from the lowest: compounds 1, 2 and 3 (each within the scatter of the next, the first and the last beyond it).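

In this assay this position on the carbonyl carbon now shows one separation, a 2.5-fold higher number from compound 1 to compound 3 (0.39 log units; beyond the scatter), with 2-methylphenyl in place of 4-chlorophenyl. The exchange of 2,4-difluorophenyl for 2-methylphenyl, a 1.4-fold higher number from compound 2 to compound 3 (0.15 log units; within the scatter), does not separate those two compounds, so the three aryl groups span only a modest range. Nothing available explains the one separation.

Open, on these data alone, is whether a non-aromatic group such as cyclohexyl or a longer alkyl chain would hold this range. Also open, as far as these compounds go, is how a phenyl ring carrying an amine or a carboxylic acid would read here.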